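From 4-methylphenyl to 2-fluorophenyl on the shared core

The source may report more compounds than this note shows. Statements on the series, on what has been measured and on what is new or still open speak of the compounds shown alone.

Measured so far in a functional assay on A-375 cells (Homo sapiens) for cytotoxicity, read by CCK-8 assay, with a stated time of 24 h (a lower number here means a stronger inhibitor, a higher number a weaker inhibitor), are these values
Compound 1 `COc1ccccc1Oc1c(N)nc(-c2ccccc2F)nc1Cl` gives > 80000 nM as a limit of the assay
Compound 2 `COc1ccccc1Oc1c(N)nc(-c2cccc(C)c2)nc1OCCO` gives 1380 nM
Compound 3 `COc1ccccc1Oc1c(N)nc(-c2ccc(C)cc2)nc1OCCO` gives 2380 nM

For the measured compounds named here, compound 3, at 2380 nM, stands within the scatter of compound 2, and the only numeric comparison available is a 1.7-fold higher number from compound 2 to compound 3 (0.24 log units; within the scatter). Going by the values given here, compound 1 is known only through a limit, (the limit of > 80000 nM in this assay, at which 1 of the 3 values shown sits), and so it offers no size of step.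

The next compound to be measured is compound 4 `COc1ccccc1Oc1c(N)nc(-c2ccccc2F)nc1OCCO`. The change leading to it is 2-fluorophenyl in place of 4-methylphenyl on an aromatic carbon. The 2-hydroxyethoxy group, the amino group and the 2-methoxyphenoxy group all stay in place.

Among the compounds with values here, one measured step bears on this change, and it concerns the same aromatic carbon: a 1.7-fold higher number from compound 2 to compound 3 (0.24 log units; within the scatter). That step exchanged one methylphenyl for another, so it is only a loose guide to a 2-fluorophenyl. No step beyond the scatter is therefore expected in this assay, in either direction, though the range is kept wide. The estimate amounts to an expected 1.1-fold lower number from compound 3 to compound 4 (0.03 log units; within the scatter) here. For compound 4 the expected value is 2200 nM, with an estimated range from 800 nM to 7000 nM in this measurement.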

Compound 4, half-maximal inhibitory concentration: > 80000 nM
Compound 4: only a limit was reported; the forecaster's own chance of this, stated with the estimate: 5%; middle value at least 36-fold (1.56 log units) away from the limit.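

In this assay, the aromatic carbon between two ring nitrogen atoms turns out to be far more sensitive to the choice of aryl group than the exchange of one methylphenyl for another had indicated: the change to 2-fluorophenyl gives an at least 33-fold higher number from compound 3 to compound 4 (1.52 log units; beyond the scatter), and likewise an at least 57-fold higher number from compound 2 to compound 4 (1.76 log units; beyond the scatter), both resting on a limit and not on a number. The 2-hydroxyethoxy group goes with measurable values alongside either methylphenyl group, yet it does not give a measurable value alongside 2-fluorophenyl, so this aryl position can outweigh what the group on the other side of the shared core contributes. Compound 4 is known only through a limit, and the step between compound 1 and compound 4 therefore cannot be read: the limit of > 80000 nM in this assay, at which 2 of the 4 values shown sit.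

Going by these compounds, it remains open whether the fluorine or its place on the ring carries this large step, a question that 3-fluorophenyl, 4-fluorophenyl, 2-methylphenyl or unsubstituted phenyl at the same carbon would address. On these data alone, it is equally open whether an amine or a longer chain in place of the 2-hydroxyethoxy group would restore a measurable value alongside 2-fluorophenyl.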